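One added methyl on compound 2

This account rests on a few compounds, and the source may have more. Where it says the series, first, only, none or still open, it means among the compounds named here.

In an ADME assay on the whole organism (Rattus norvegicus, strain Sprague-Dawley) for pharmacokinetics, with a stated time of 6 h, at a dose of 10 mg/kg by the oral route (a higher number here means more compound in the circulation at the dose given, a lower number less compound in the circulation), compound 1 `Cc1cn2cc(-c3cc4ccc(N5CCN(C)CC5)cc4c(=O)o3)nc2c(C)n1` gives 790 ng.h/mL while compound 2 `Cc1cn2cc(-c3cc4ccc(N5CCN(C)[C@@H](C)C5)cc4oc3=O)nc2c(C)n1` gives 260 ng.h/mL as the lower of the two numbers, and that gap lies beyond the usual scatter. Compound 3 `CCN1CCN(c2ccc3cc(-c4cn5cc(C)nc(C)c5n4)c(=O)oc3c2)C[C@@H]1C` differs from compound 2 by one change: methyl in place of hydrogen on a saturated chain carbon bound to an amine nitrogen in a ring with methyl in place of hydrogen on a saturated chain carbon bound to an amine nitrogen in a ring, so that methyl becomes ethyl. Going by the values given here, no measured pair shows this change. The estimated 1.1-fold lower number from compound 2 to compound 3 (0.03 log units; within the scatter) in this assay is expected to stay within the scatter. For compound 3 the expected value is 240 ng.h/mL with 90 ng.h/mL to 640 ng.h/mL as its range.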

Compound 3, area under the concentration-time curve: 1100 ng.h/mL
Beside the measured number, compound 3's estimate is 4.6-fold (0.66 log units) below it, and the stated range ends below it.
By their numbers in this assay, from the lowest: compound 2; then compounds 1 and 3 (each within the scatter of the next).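

In this assay, going by these compounds alone, the change from 3,4-dimethylpiperazin-1-yl to 4-ethyl-3-methylpiperazin-1-yl gives a 4.2-fold higher number from compound 2 to compound 3 (0.63 log units; beyond the scatter) and so provides the first step that can be read here. It shows that one added methyl, turning methyl into ethyl, can move this number beyond the scatter. Nothing available explains this rise. As far as these compounds go, whether a longer chain such as propyl or a ring such as cyclopropyl in place of the ethyl would raise the number further remains open. One pair also cannot show whether the step would hold on another core.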